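Swapping the ring-nitrogen cap while the rest stays unchanged

The compounds below may be only part of what the source reports. "The series", "measured", "known", "first", "only" and "open" are said of these compounds alone.

Of the compounds shown here, three of one family have been tested in a functional assay on HCC1806 cells (Homo sapiens) for inhibition, read by sulforhodamine B assay, tested at 10 uM; a lower number here means less inhibition, a higher number more inhibition at the concentration tested (going by the name of the read-out). Compound 1 `Cc1ccc(S(=O)(=O)N2N=C(c3ccc(N4CCN(C)CC4)cc3)CC2c2ccc(N(C)C)cc2)cc1` gives 32.2%, compound 2 `Cc1ccc(S(=O)(=O)N2N=C(c3ccc(-n4cncn4)cc3)CC2c2ccc(N(C)C)cc2)cc1` gives 27.7%, and compound 3 `CN(C)c1ccc(C2CC(c3ccc(-n4ccnc4)cc3)=NN2C(=O)c2ccc(C(F)(F)F)cc2)cc1` gives 28%. Compound 3 stands second highest of the three, yet its gaps to both neighbours lie within the scatter. Among the measured compounds shown here, the one measured step, a number 4.5 percentage points lower from compound 1 to compound 2 (within the scatter), concerns a different part of the shared core, so it does not bear on the new change. Compound 4 `Cc1ccc(S(=O)(=O)N2N=C(c3ccc(-n4ccnc4)cc3)CC2c2ccc(N(C)C)cc2)cc1` differs from compound 3 by (4-methylphenyl)sulfonyl in place of (4-(trifluoromethyl)phenyl)carbonyl on an amine nitrogen in a ring. Compounds 1 and 2 already carry that sulfonyl group and sit close to compound 3, so the estimated step of a number 1 percentage points higher from compound 3 to compound 4 (within the scatter) is expected to stay within the scatter. Compound 4 is therefore estimated at 29%, in the range 18% to 40%.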

Compound 4, a percentage reported as inhibition, at one concentration (the size of the read-out at that concentration, not a potency): 66%
For compound 4 the middle estimate is 37 percentage points below the measured one; measured number outside the range, above it.
By their numbers in this assay, from the lowest: compounds 2, 3 and 1 (each within the scatter of the next); then compound 4.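

In this assay the cap on the ring nitrogen matters a great deal: (4-methylphenyl)sulfonyl in place of (4-(trifluoromethyl)phenyl)carbonyl gives a number 38 percentage points higher from compound 3 to compound 4 (beyond the scatter). The sulfonyl cap is not enough by itself, as compound 1 and compound 2 carry it too: 1H-imidazol-1-yl gives a number 38.3 percentage points higher from compound 2 to compound 4 (beyond the scatter) against 1H-1,2,4-triazol-1-yl and a number 33.8 percentage points higher from compound 1 to compound 4 (beyond the scatter) against 4-methylpiperazin-1-yl. Among these four compounds, only this pairing of cap and ring stands out, and nothing measured here explains why. As far as these compounds go, whether a smaller methanesulfonyl cap would hold this level remains open, as does the effect of a primary amine in place of the 1H-imidazol-1-yl group.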